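The compounds below may be only part of what the source reports. "The series", "measured", "known", "first", "only" and "open" are said of these compounds alone.

In a functional assay on HeLa cells (Homo sapiens) for antiproliferative activity, with a stated time of 48 h (on this read-out lower numbers stand for stronger inhibition and higher numbers for weaker inhibition), compound 3 `Nc1ccc(/C=C/C(=O)c2ccccc2)cc1` gives 36000 nM, the highest of the three numbers, while compound 1 `C=C(Br)C(=O)Nc1ccc(/C=C/C(=O)c2ccccc2)cc1` gives 3900 nM and compound 2 `C=C(Br)C(=O)Nc1ccc(C(=O)/C=C/c2ccc(N(C)C)cc2)cc1` gives 610 nM. Compound 4 `COc1ccc(C(=O)/C=C/c2ccc(N)cc2)cc1` carries methoxy in place of hydrogen on an aromatic carbon of compound 3: methoxy in place of hydrogen on an aromatic carbon. Going by the values given here, the only measured step, a 9.2-fold higher number from compound 1 to compound 3 (0.97 log units; beyond the scatter), puts hydrogen in place of (1-bromoethenyl)carbonyl on the nitrogen. Among the compounds with values here, it leaves the carbon that changes here untouched, so it bears only weakly on this change, and no measured step shows what methoxy does. A small move towards a lower number in this assay, not clearly beyond the scatter, is expected: a 1.8-fold lower number from compound 3 to compound 4 (0.26 log units; within the scatter). The estimated value for compound 4 is 20000 nM, with an expected range from 6000 nM to 60000 nM.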

Compound 4, half-maximal inhibitory concentration: 98000 nM
The estimate for compound 4 lay 4.9-fold (0.69 log units) below the measured number; the whole stated range lies below it.
By their numbers in this assay, from the lowest: compound 2; then compound 1; then compound 3; then compound 4.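

In (this assay), methoxy in place of hydrogen on an aromatic carbon, para to a large group, gives a weaker result (a 2.7-fold higher number from compound 3 to compound 4 (0.43 log units; beyond the scatter)), so this carbon does not tolerate the change without loss. Going by these compounds alone, this is the first measured change at this carbon, as the earlier step altered only the nitrogen. No measured evidence here accounts for the loss. On these data alone, it remains open whether fluoro, methyl or hydroxyl at this carbon would shift the number the same way. As far as these compounds go, it also remains open whether methoxy acts alike when the nitrogen carries (1-bromoethenyl)carbonyl.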